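Fluoro-to-hydrogen step on the shared core, cytotoxicity read-out

The source may hold more compounds than are shown below. What is called first, only, known or untested is meant among the compounds shown, and "the series" means these compounds.

Measured in a functional assay on A549 cells (Homo sapiens) for cytotoxicity, read by colorimetric assay and MTT assay, with a stated time of 3 days, tested at 1 uM; a lower number here means a stronger effect, a higher number a weaker effect of the compound at the concentration tested:
compound 1 `O=C1COc2ccc(-c3[nH]c(-c4ccc(F)cc4)nc3-c3ccccc3)cc2N1` gives 97.1%
compound 2 `O=C1COc2ccc(-c3nn(-c4ccc(F)cc4)cc3-c3ccccc3)cc2N1` gives 78.2%
compound 3 `O=C1COc2ccc(-c3nn(-c4cc(Cl)cc(Cl)c4)cc3-c3ccccc3)cc2N1` gives 93.1%

Compound 1 holds the top number of the three, yet compound 3 lies within the scatter of it; only compound 2 is beyond it. Among the compounds with values here, the single measured step, a number 14.9 percentage points higher from compound 2 to compound 3 (beyond the scatter), swaps the aryl group on an aromatic nitrogen and does not touch the place changed here.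

Compound 4 `O=C1COc2ccc(-c3[nH]c(-c4ccccc4)nc3-c3ccccc3)cc2N1` differs from compound 1 by hydrogen in place of fluoro on an aromatic carbon. Within the data shown here, no measured step bears on this change, so nothing in the data argues for a shift beyond the scatter in this assay; a step of about a number 2.1 percentage points lower from compound 1 to compound 4 (within the scatter) is expected. Compound 4 is estimated at 95%, with a range from 84% to 103%.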

Compound 4, a percentage reported as activity, at one concentration (the size of the read-out at that concentration, not a potency): 95.6%
The estimate for compound 4 lay 0.6 percentage points below the measured number; the range from low to high includes it.
By their numbers in this assay, from the lowest: compound 2; then compounds 3, 4 and 1 (each within the scatter of the next).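

In this assay, within the data shown here, the change from 4-fluorophenyl to phenyl gives a number 1.5 percentage points lower from compound 1 to compound 4 (within the scatter) and is the first measured step at this place on the shared core. Hydrogen and fluoro on this aromatic carbon therefore cannot be told apart in this read-out. No available evidence bears on this result.

Going by these compounds, whether an amine or a carboxylic acid at this place would move the number beyond the scatter remains open. So does whether the same change would give a comparable step on the core of compound 2.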